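The source may report more compounds than this note shows. Statements on the series, on what has been measured and on what is new or still open speak of the compounds shown alone.

Working notes on the series, following the step from compound 2 to compound 4. Compound 2 (`CS(=O)(=O)c1c(CCc2ccccc2)c2cc(OCC(=O)NCC3CC3)ccc2[nH]c1=O`) has no single number to place it in an ADME assay on microsomes from liver (Homo sapiens) for metabolic stability, with a stated time of 0.5 h; a higher number here means that more of the compound is left, a lower number that less of the compound is left: the entry for compound 2 reads "not determined" (no result reported) and so no rank can be given. Compound 1 (`CC(C)(NC(=O)COc1ccc2[nH]c(=O)c(-c3ccccn3)c(CCc3ccccc3)c2c1)c1ccccc1`) is in the same position, with "not determined" (no result reported) as its entry. Within the data shown here, compound 3 (`CC(C)(NC(=O)NCc1ccc2[nH]c(=O)c(-c3nccs3)c(CCc3ccccc3)c2c1)c1ccccc1`) is the only one with a number, and compound 3 gives 40% as the sole measured level.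

Compound 4 (`CN(Cc1ccc(Cl)c(Cl)c1)C(=O)COc1ccc2[nH]c(=O)c(S(C)(=O)=O)c(CCc3ccccc3)c2c1`) has not yet been measured. The structural change is (3,4-dichlorobenzyl)(methyl)amino in place of (cyclopropylmethyl)amino on a carbonyl carbon and amounts to (3,4-dichlorobenzyl)(methyl)amino in place of (cyclopropylmethyl)amino on a carbonyl carbon.

Among the measured compounds shown here, no measured pair exists, so the data give no size for any step. As a judgement only, a moderate downward step in this assay is expected for this change, and the direction remains uncertain. The level of the estimate rests on compound 3 at 40% and is loose, as compound 3 also differs from compound 4 in other places. For compound 4 the expected value is 30% with an estimated range from 10% to 60% in this read-out.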

Compound 4, percent of the compound remaining: 0%
Compound 4: middle estimate off by 30 percentage points, on the high side, and the stated range ends above it.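

Among these compounds, no step from compound 2 to compound 4 can be read in this assay: compound 4 gives 0% and compound 2 carries only the entry "not determined" (no result reported) without a single number. The compounds shown leave open what (3,4-dichlorobenzyl)(methyl)amino in place of (cyclopropylmethyl)amino does on its own to the percent remaining. Nothing at hand bears on this result.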